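A chlorine added to the trifluoromethylphenyl ring of compound 1

The source may report more compounds than this note shows. Statements on the series, on what has been measured and on what is new or still open speak of the compounds shown alone.

For the measured compounds named here, compound 1, with the structure `CC/C(=C(/c1ccc(/C=C/C(=O)O)cc1)c1cc2ccccc2[nH]1)c1ccccc1C(F)(F)F`, stands lowest of the three compounds measured so far in a functional assay on MCF7 cells (Homo sapiens) for inhibition (on this read-out lower numbers stand for stronger inhibition and higher numbers for weaker inhibition), giving 8 nM. Its nearest neighbour is compound 3, `CC/C(=C(/c1ccc(/C=C/C(=O)O)cc1)c1cc2ccccc2[nH]1)c1ccc(C#N)cc1Cl`, which in this assay gives 49 nM; the step of a 6.1-fold higher number from compound 1 to compound 3 (0.79 log units; beyond the scatter). The furthest is compound 2, `CC/C(=C(/c1ccc(/C=C/C(=O)O)cc1)c1cc2ccccc2[nH]1)c1ccccc1OC(F)(F)F`, which in this assay gives 206 nM, a change of a 26-fold higher number from compound 1 to compound 2 (1.41 log units; beyond the scatter). Between the two weaker compounds the step of a 4.2-fold lower number from compound 2 to compound 3 (0.62 log units; beyond the scatter).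

Compound 4, `CC/C(=C(/c1ccc(/C=C/C(=O)O)cc1)c1cc2ccccc2[nH]1)c1ccc(Cl)cc1C(F)(F)F`, has not yet been measured. It differs from compound 1 by chloro in place of hydrogen on an aromatic carbon, so that the 2-(trifluoromethyl)phenyl group becomes 4-chloro-2-(trifluoromethyl)phenyl. Both measured steps away from compound 1 went in the weaker direction, but neither of them is a simple addition of one chlorine, and the trifluoromethyl group of compound 1 is kept here. On that basis compound 4 is expected to stay close to compound 1, with at most a modest rise, a 1.9-fold higher number from compound 1 to compound 4 (0.27 log units; within the scatter), in this assay. The estimate for compound 4 is 15 nM, with a range from 5 nM to 50 nM.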

Compound 4, half-maximal inhibitory concentration: 4 nM
Estimate against measurement, compound 4: 3.8-fold (0.57 log units) above, and the stated range ends above it.
By their numbers in this assay, from the lowest: compounds 4 and 1 (each within the scatter of the next); then compound 3; then compound 2.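

In this assay, chloro in place of hydrogen on this aromatic carbon, meta to the trifluoromethyl group and para to a large group, is the only step shown from compound 1 that stays within the scatter, with a 2.0-fold lower number from compound 1 to compound 4 (0.30 log units; within the scatter). The 4-chloro-2-(trifluoromethyl)phenyl group also keeps the number well apart from the other two ring variants, with a 12-fold lower number from compound 3 to compound 4 (1.09 log units; beyond the scatter) and a 52-fold lower number from compound 2 to compound 4 (1.71 log units; beyond the scatter), so this ring carbon accepts a chlorine while the low number of compound 1 is kept. No measurement at hand gives a reason for this result.

The compounds shown leave open whether this carbon accepts groups other than chloro, such as fluoro, methoxy or a dimethylamino group. They also leave open whether chloro here would give a similar result with trifluoromethoxy in place of trifluoromethyl.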